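Swapping Methoxy for Cyano on the Anilino Ring

A few compounds are considered here, and "the series" means these few. Any claim that something is new, unique, unknown or untested is made for them only; others in the source may bear on it.

In a functional assay on A549 cells (Homo sapiens) for inhibition, read by MTT assay, with a stated time of 72 h (on this read-out lower numbers stand for stronger inhibition and higher numbers for weaker inhibition), compound 1 `C=CC(=O)Nc1cccc(Oc2nc(Nc3cccc(OC)c3)nc3ccsc23)c1` gives 4340 nM, the lower of the two numbers recorded so far. For the measured compounds named here, the only other measured compound is compound 2 `COc1cccc(Nc2nc(Oc3cccc(NC(=O)/C=C/C(C)C)c3)c3sccc3n2)c1`, which in this assay gives 4340 nM for compound 1 against 37100 nM for compound 2, a step of an 8.5-fold higher number from compound 1 to compound 2 (0.93 log units; beyond the scatter). That step, however, alters the group on the carbonyl carbon and leaves the anilino ring untouched.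

Compound 3 `C=CC(=O)Nc1cccc(Oc2nc(Nc3cccc(C#N)c3)nc3ccsc23)c1` differs from compound 1 elsewhere: cyano in place of methoxy on an aromatic carbon. Going by the values given here, no measured pair speaks to this change, so the single recorded step gives no guidance on its direction or size. In the absence of any comparable step, compound 3 is expected to stay close to compound 1, with a step of a 1.2-fold higher number from compound 1 to compound 3 (0.06 log units; within the scatter) that does not go beyond the scatter, though the uncertainty is wide. The estimate for compound 3 in this assay is therefore 5000 nM, with a range from 1500 nM to 17000 nM.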

Compound 3, half-maximal inhibitory concentration: 4340 nM
For compound 3 the middle estimate is 1.2-fold (0.06 log units) above the measured one, within the range that was stated.
By their numbers in this assay, from the lowest: compounds 1 and 3 (each within the scatter of the next); then compound 2.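

In this assay, the swap on this ring gives its first reading, no change at the digits printed from compound 1 to compound 3 (within the scatter), so cyano in place of methoxy on an aromatic carbon, meta to a large group, leaves the number where it stood. The one earlier step, an 8.5-fold higher number from compound 1 to compound 2 (0.93 log units; beyond the scatter), came from a change at the carbonyl carbon and went beyond the scatter, so among the compounds shown, that site responds to its change while this position does not respond to this one. Nothing available explains why methoxy and cyano read alike here, and the result rests on this single pair of compounds.

One exchange between two groups says little about how this aromatic carbon would respond to something different in kind, such as an amine, a carboxylic acid or a longer chain like butoxy. On these data alone, it also remains open whether cyano would read the same as methoxy when paired with the 3-methylbut-1-en-1-yl group of compound 2, or whether the two changes would interact on the shared core.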